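The source may hold more compounds than are shown below. What is called first, only, known or untested is meant among the compounds shown, and "the series" means these compounds.

In a functional assay (strain AB) with Danio rerio as the target, read by microscopy, with a stated time of 1 h (on this read-out higher numbers stand for an effect only at larger amounts of compound and lower numbers for an effect already at smaller amounts), compound 1 `NC(=O)c1c(NC(=O)Nc2ccc(Cl)cc2)sc2c1CCN(CC1CCCCC1)C2` gives 1890 nM, compound 2 `NC(=O)c1c(NC(=O)Nc2ccc(Cl)cc2)sc2c1CCN(C1CCOCC1)C2` gives 2830 nM and compound 3 `CC(C)(C)CN1CCc2c(sc(NC(=O)Nc3ccc(Cl)cc3)c2C(N)=O)C1` gives 5560 nM. Going by the values given here, compound 3 therefore stands apart from only one of the other two: the comparison with compound 1 shows a 2.9-fold higher number from compound 1 to compound 3 (0.47 log units; beyond the scatter), while the one with compound 2 shows a 2.0-fold higher number from compound 2 to compound 3 (0.29 log units; within the scatter).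

The next compound, compound 4 `CC(C)(C)OC(=O)CCN1CCc2c(sc(NC(=O)Nc3ccc(Cl)cc3)c2C(N)=O)C1`, keeps the shared core and carries (tert-butoxycarbonyl)methyl in place of tert-butyl on a saturated chain carbon bound to an amine nitrogen in a ring, which amounts to (tert-butoxycarbonyl)methyl in place of tert-butyl on a saturated chain carbon bound to an amine nitrogen in a ring. Cut one bond further out, this is neopentyl to 2-(tert-butoxycarbonyl)ethyl.

Among the compounds with values here, the closest precedent is the change at that same carbon, a 2.9-fold higher number from compound 1 to compound 3 (0.47 log units; beyond the scatter), and it is the only step so far that goes beyond the scatter. The change on the ring nitrogen itself gave a 1.5-fold higher number from compound 1 to compound 2 (0.18 log units; within the scatter). None of the three measured compounds carries a carbonyl in this substituent, so these steps offer only a loose guide, but all of them are small. No step beyond the scatter is therefore expected in this assay, and the expected step is a 1.4-fold lower number from compound 3 to compound 4 (0.14 log units; within the scatter).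

For compound 4 the estimated value is 4000 nM, with an expected range from 1500 nM to 11000 nM.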

Compound 4, half-maximal effective concentration: 1100 nM
Beside the measured number, compound 4's estimate is 3.6-fold (0.56 log units) above it; the whole stated range lies above it.
By their numbers in this assay, from the lowest: compounds 4, 1, 2 and 3 (each within the scatter of the next, the first and the last beyond it).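

In this assay, the substituent at this position, on a saturated chain carbon bound to an amine nitrogen in a ring, proved able to lower the number as well as raise it: the exchange of tert-butyl for (tert-butoxycarbonyl)methyl gives a 5.1-fold lower number from compound 3 to compound 4 (0.70 log units; beyond the scatter), the largest step in the series, and the first one here made by a group that carries a carbonyl. The same substituent also separates compound 4 from the ring-bearing oxan-4-yl analogue, with a 2.6-fold lower number from compound 2 to compound 4 (0.41 log units; beyond the scatter), yet it does not separate it from the cyclohexylmethyl analogue, with a 1.7-fold lower number from compound 1 to compound 4 (0.24 log units; within the scatter), so an open chain with an ester and a chain ending in a cyclohexyl ring are not told apart in this assay. Nothing available explains these steps.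

Compound 4 differs from compound 3 in chain length, carbonyl and ester oxygen all at once, so the compounds shown do not tell which of these features goes with the lower number. A plain pentyl chain, a methyl ester or a carboxylic acid on the same nitrogen would be the groups to separate them.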